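A few compounds are considered here, and "the series" means these few. Any claim that something is new, unique, unknown or untested is made for them only; others in the source may bear on it.

Measured in a functional assay on MDA-MB-231 cells (Homo sapiens) for inhibition, read by MTT assay, with a stated time of 72 h; a higher number here means a weaker inhibitor, a lower number a stronger inhibitor:

- Compound 1 `CC(C)[C@H](NC(=O)c1cc(Cl)ccc1OCCN)C(=O)Nc1ccc([N+](=O)[O-])cc1Cl` gives > 10000 nM (a limit).
- Compound 2 `COC(=O)NCCOc1ccc(Cl)cc1C(=O)N[C@H](C(=O)Nc1ccc([N+](=O)[O-])cc1Cl)C(C)C` gives > 10000 nM (a limit).
- Compound 3 `CC(C)COC(=O)NCCOc1ccc(Cl)cc1C(=O)N[C@H](C(=O)Nc1ccc([N+](=O)[O-])cc1Cl)C(C)C` gives 4900 nM as a number.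

Compound 3 alone carries a true number, 4900 nM in this set. Instead of a number, compound 1 and compound 2 give (the limit of > 10000 nM in this assay, at which 2 of the 3 values shown sit).

Compound 4 `CC(C)[C@H](NC(=O)c1cc(Cl)ccc1OCCCN)C(=O)Nc1ccc([N+](=O)[O-])cc1Cl` arises through aminomethyl in place of (isobutoxycarbonyl)amino on a saturated chain carbon, two bonds along the chain from an oxygen on an aromatic ring.

The closest measured step is an at least 2.0-fold lower number from compound 1 to compound 3 (0.30 log units; that floor lies within the scatter), which adds isobutoxycarbonyl to a free amine. Compound 4 loses that group, so with compound 1 as the guide, a higher number is expected in this assay. The expected change is a 2.4-fold higher number from compound 3 to compound 4 (0.39 log units; beyond the scatter), possibly reported only as a limit. For compound 4 the estimate is 12000 nM, with an expected range of 5000 nM to 30000 nM.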

Compound 4, half-maximal inhibitory concentration: 6770 nM
For compound 4 the middle estimate is 1.8-fold (0.25 log units) above the measured one, within the range that was stated.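

Aminomethyl in place of amino on that chain carbon gives the free amine a true number in this assay, a step that reads an at least 1.4-fold lower number from compound 1 to compound 4 (0.16 log units; that floor lies within the scatter). The same chain also gives an at least 1.4-fold lower number from compound 2 to compound 4 (0.16 log units; that floor lies within the scatter), while a 1.4-fold higher number from compound 3 to compound 4 (0.14 log units; within the scatter) means that the 3-aminopropoxy chain and the 2-((isobutoxycarbonyl)amino)ethoxy chain cannot be told apart here. Compound 1 and compound 2 each stand at a limit, so those two steps are floors only: the limit of > 10000 nM in this assay, at which 2 of the 4 values shown sit.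

Still open, going by these compounds, is whether an isobutoxycarbonyl group on the 3-aminopropoxy chain would change the number. A longer chain ending in an amine, or a chain ending in a carboxylic acid, also remains untested in what is shown here.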